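Sulfone variation on a shared core: compound 3 expected

This account rests on a few compounds, and the source may have more. Where it says the series, first, only, none or still open, it means among the compounds named here.

Measured so far:
compound 1 `Cn1c(=O)c(S(=O)(=O)Cc2ccc(F)cc2F)cc2cnc(Nc3ccc4[nH]ccc4c3)nc21`: 1000 nM
compound 2 `O=c1c(S(=O)(=O)c2ccc(F)cc2F)cc2cnc(Nc3ccc4[nH]ccc4c3)nc2n1C1CC1`: 500 nM

In a functional assay on DU-145 cells (Homo sapiens) for inhibition, read by trypan blue exclusion, with a stated time of 72 h (a lower number here means a stronger inhibitor, a higher number a weaker inhibitor), compound 1 gives 1000 nM. Compound 2 gives 500 nM in this assay. Compound 1 holds the higher of the two numbers, but its gap to compound 2 lies within the usual scatter, so neither compound can be called the stronger inhibitor on these data.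

Compound 3 `Cn1c(=O)c(S(=O)(=O)c2ccc([N+](=O)[O-])cc2F)cc2cnc(Nc3ccc4[nH]ccc4c3)nc21` is not yet measured. It differs from compound 1 in one place: 2-fluoro-4-nitrophenyl in place of 2,4-difluorobenzyl on a sulfonyl sulfur. Among the compounds with values here, no pair of measured compounds shows the effect of such a change on the sulfonyl sulfur, so there is no step to lean on; the two measured values only show that the core tolerates variation elsewhere without leaving the scatter. Compound 3 is therefore expected to land near compound 1, with a step of no change at the digits printed from compound 1 to compound 3 (within the scatter) of no clear direction beyond the scatter. The estimate for compound 3 in this assay is 1000 nM, within 300 nM to 3500 nM.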

Compound 3, half-maximal inhibitory concentration: 400 nM
Estimate against measurement, compound 3: 2.5-fold (0.40 log units) above, within the range that was stated.
By their numbers in this assay, from the lowest: compounds 3, 2 and 1 (each within the scatter of the next, the first and the last beyond it).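

Within the data shown here, on the sulfonyl sulfur, 2-fluoro-4-nitrophenyl in place of 2,4-difluorobenzyl gives a 2.5-fold lower number from compound 1 to compound 3 (0.40 log units; beyond the scatter) in this assay, the first change that can be read at a single place on the shared core. The group on the sulfonyl sulfur therefore moves the number beyond the scatter, although the step is modest. No measurement shown bears on why this step occurs.

Still open, on these data alone, is whether the step follows the nitro group or the exchange of a benzyl for a phenyl group, as this single pair changes both at once. A 2,4-difluorophenyl group on the sulfonyl sulfur of the core of compound 1 would separate the two, and an amine or a carboxylic acid in place of the nitro group would test how far this position tolerates other groups.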